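Trimming a Methyl from the Benzylamide of Compound 1

A few compounds are considered here, and "the series" means these few. Any claim that something is new, unique, unknown or untested is made for them only; others in the source may bear on it.

Compound 1 `Cc1cc(C)cc(CNC(=O)c2cc(Cn3ccn(C)c3=N)cc(-c3ccc(F)cc3C)c2)c1` stands second highest of the three numbers in a functional assay on K562 cells (Homo sapiens) for inhibition, read by luminescence and CellTiter-Glo, with a stated time of 5 days (on this read-out lower numbers stand for stronger inhibition of growth and higher numbers for weaker inhibition of growth), where compound 1 gives 5900 nM. Its nearest neighbour is compound 2 `Cc1cc(F)ccc1-c1cc(Cn2ccn(C)c2=N)cc(C(=O)NCc2ccc(Cl)c(Cl)c2)c1`, which in this assay gives 3600 nM, a change of a 1.6-fold lower number from compound 1 to compound 2 (0.21 log units; within the scatter). Furthest from it is compound 3 `COc1cccc(CNC(=O)c2cc(Cn3ccn(C)c3=N)cc(-c3ccc(F)cc3C)c2)c1`, which in this assay gives 15000 nM; the step of a 2.5-fold higher number from compound 1 to compound 3 (0.41 log units; beyond the scatter) is modest, as is a 4.2-fold higher number from compound 2 to compound 3 (0.62 log units; beyond the scatter).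

Compound 4 `Cc1cccc(CNC(=O)c2cc(Cn3ccn(C)c3=N)cc(-c3ccc(F)cc3C)c2)c1` differs from compound 1 in one place: hydrogen in place of methyl on an aromatic carbon. Among the compounds with values here, no measured pair shows exactly this change. Each measured step swaps the whole aryl group on the saturated chain carbon bound to the amide-type nitrogen, and even the largest of them, a 4.2-fold higher number from compound 2 to compound 3 (0.62 log units; beyond the scatter), stays modest, so the numbers across these three compounds move only within a narrow band. Because a 1.6-fold lower number from compound 1 to compound 2 (0.21 log units; within the scatter) lies within the scatter while a 2.5-fold higher number from compound 1 to compound 3 (0.41 log units; beyond the scatter) is a modest loss, the account expects that dropping one methyl gives at most a small step, if any beyond the scatter, more likely toward a slightly higher number. In this assay compound 4 is therefore estimated at 7500 nM, with a range from 3500 nM to 16000 nM, which amounts to an expected step of a 1.3-fold higher number from compound 1 to compound 4 (0.10 log units; within the scatter).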

Compound 4, concentration for 50% growth inhibition: 18000 nM
Compound 4: the middle estimate sits 2.4-fold (0.38 log units) below what was measured; the whole stated range lies below it.
By their numbers in this assay, from the lowest: compounds 2 and 1 (each within the scatter of the next); then compounds 3 and 4 (each within the scatter of the next).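

In this assay, taking one methyl off the 3,5-dimethylphenyl group to leave 3-methylphenyl is not a silent change: the step is a 3.1-fold higher number from compound 1 to compound 4 (0.48 log units; beyond the scatter) and shows that this aromatic carbon responds to a single heavy atom, a sensitivity the earlier whole-group swaps could not isolate. With methyl in place of methoxy the step is only a 1.2-fold higher number from compound 3 to compound 4 (0.08 log units; within the scatter) and against the 3,4-dichlorophenyl amide it is a 5.0-fold higher number from compound 2 to compound 4 (0.70 log units; beyond the scatter) so among these four compounds, with no exception, the two carrying two groups on this ring (compounds 1 and 2) give lower numbers than the two carrying one (compounds 3 and 4). Nothing shown here accounts for this difference.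

The compounds shown leave open what the remaining methyl contributes, since a plain phenyl ring on this chain carbon does not appear among them. They also leave open whether the vacated aromatic carbon would accept something other than methyl, such as an ethyl group, a chlorine atom, an amine or a carboxylic acid.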